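A few compounds are considered here, and "the series" means these few. Any claim that something is new, unique, unknown or untested is made for them only; others in the source may bear on it.

Measured so far in a functional assay on HL-60 cells (Homo sapiens) for antiproliferative activity, read by XTT assay, with a stated time of 72 h; on this read-out lower numbers stand for stronger inhibition and higher numbers for weaker inhibition:
compound 1 `Cc1ncnc2c1c(-c1ccoc1)cn2[C@@H]1O[C@H](CO)[C@@H](O)[C@H]1O`: > 15000 nM
compound 2 `Nc1nc2c(c(-c3cccs3)cn2[C@@H]2O[C@H](CO)[C@@H](O)[C@H]2O)c(=O)[nH]1`: > 20000 nM
compound 3 `Cc1ncnc2c1c(-c1cccs1)cn2[C@@H]1O[C@H](CO)[C@@H](O)[C@H]1O`: 5730 nM

The value of compound 1 is a limit of the assay, not a number (the limit of > 15000 nM in this assay, at which 1 of the 3 values shown sits). The value of compound 2 is likewise a limit (the limit of > 20000 nM in this assay, at which 1 of the 3 values shown sits). Only compound 3 gives a number. The change furan-3-yl in place of thiophen-2-yl on an aromatic carbon made an at least 2.6-fold higher number from compound 3 to compound 1 (0.41 log units; beyond the scatter), that is, it weakened the inhibition. Compound 2 and compound 3 share only part of their structure; the difference between the two cores is not broken down here.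

Compound 4 `Nc1nc2c(c(-c3ccoc3)cn2[C@@H]2O[C@H](CO)[C@@H](O)[C@H]2O)c(=O)[nH]1` arises from compound 2 by furan-3-yl in place of thiophen-2-yl on an aromatic carbon, the same change as before, at the same place. Compound 2 already stands at a limit, > 20000 nM. The step expected here is a step that the limit leaves unreadable from compound 2 to compound 4, most likely a further limit and no number, resting on compound 3 whose same change gave an at least 2.6-fold higher number from compound 3 to compound 1 (0.41 log units; beyond the scatter). Compound 4 is therefore estimated at about 40000 nM, within 20000 nM to 100000 nM.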

Compound 4, half-maximal inhibitory concentration: > 15000 nM
Compound 4: only a limit was reported; the forecaster's own chance of this, stated with the estimate: 90%; the middle value does not contradict the limit.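

Compound 2 and compound 4 both give only limits and not numbers, so no step can be read between them. Going by these compounds, how far furan-3-yl in place of thiophen-2-yl shifts inhibition on the core of compound 2 stays open.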